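Hydroxy on the benzylamine arm of a pyroglutamide amidine

The source may hold more compounds than are shown below. What is called first, only, known or untested is meant among the compounds shown, and "the series" means these compounds.

Measured so far:
Compound 1, `N=C(NCc1ccc(O)cc1)[C@@H]1CCC(=O)N1Cc1ccccc1`, gives 35.4%.
Compound 2, `N=C(NCc1ccccc1)[C@@H]1CCC(=O)N1Cc1ccc([N+](=O)[O-])cc1`, gives 24%.

The two compounds were tested in a functional assay on SH-SY5Y cells (Homo sapiens) for cytotoxicity, read by MTT assay, with stated times of 8 h, 30 min and 12 h, tested at 0.5 uM (a lower number here means a weaker effect, a higher number a stronger effect of the compound at the concentration tested), a read-out of how strongly each compound reduces the viability of the cells at a single concentration. Compound 2 gives the lower of the two numbers, and its distance from compound 1 lies beyond the usual scatter of this kind of measurement. The two compounds differ in more than one place, so the gap between them cannot be assigned to a single group; it is simply what the two values show.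

The next compound, compound 3, `N=C(NCc1ccc(O)cc1)[C@@H]1CCC(=O)N1Cc1ccc([N+](=O)[O-])cc1`, is built from compound 2 by one change: hydroxy in place of hydrogen on an aromatic carbon. Within the data shown here, compound 1 carries the same hydroxy group, but no step for this change alone has been measured, so its effect in this assay is open. The expected step of a number 5 percentage points higher from compound 2 to compound 3 (within the scatter) is small and, if anything, upward, and it may well stay within the scatter. Compound 3 is therefore estimated at 29%, within a range from 16% to 42%.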

Compound 3, a percentage reported as activity, at one concentration (the size of the read-out at that concentration, not a potency): 31.3%
The estimate for compound 3 lay 2.3 percentage points below the measured number; low and high end bracket the measured number.
By their numbers in this assay, from the lowest: compounds 2, 3 and 1 (each within the scatter of the next, the first and the last beyond it).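

Among these compounds, compound 3 provides the first steps that change only one place. In this assay, hydroxy in place of hydrogen on an aromatic carbon, turning benzyl into 4-hydroxybenzyl on the amidine arm, gives a number 7.3 percentage points higher from compound 2 to compound 3 (within the scatter), and nitro in place of hydrogen on an aromatic carbon gives a number 4.1 percentage points lower from compound 1 to compound 3 (within the scatter). Neither single change can therefore be told apart from the scatter, even though compound 1 and compound 2, which differ in both places, lie beyond it, so the gap between those two cannot be pinned on either group alone. No measurement at hand explains these numbers.

As far as these compounds go, it remains open what an amine, a carboxylic acid or a methoxy group would give in place of the hydroxy on this aromatic carbon, and whether any of them would move the number beyond the scatter. All three numbers also come from a single concentration, so they leave open how the compounds would compare across a range of concentrations.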